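This account rests on a few compounds, and the source may have more. Where it says the series, first, only, none or still open, it means among the compounds named here.

Compound 1 `O=C(Nc1cc(C(F)(F)F)cc(C(F)(F)F)c1)c1ccc(Sc2ccc(O)cc2)cc1`, 5600 nM
Compound 2 `O=C(Nc1cc(C(F)(F)F)ccc1C(F)(F)F)c1ccc(Sc2ccc(O)cc2)cc1`, 16600 nM
Compound 3 `O=C(Nc1cc(C(F)(F)F)cc(C(F)(F)F)c1)c1ccc(S(=O)(=O)c2ccc(O)cc2)cc1`, 9920 nM

All three numbers come from a functional assay on DU-145 cells (Homo sapiens) for antiproliferative activity, read by fluorescence and propidium iodide staining, with a stated time of 96 h; on this read-out lower numbers stand for stronger inhibition and higher numbers for weaker inhibition. Compound 1 and compound 2 are built from the same atoms joined differently; the difference between the two cores is not broken down here. What the values show is that compound 2 sits beyond the usual scatter from compound 1, while compound 2 and compound 3 lie within the scatter of each other. Compound 3 is compound 1 with one change, ((4-hydroxyphenyl)sulfonyl in place of (4-hydroxyphenyl)sulfanyl on an aromatic carbon), and that step was a 1.8-fold higher number from compound 1 to compound 3 (0.25 log units; within the scatter). Compound 4 `O=C(Nc1cc(C(F)(F)F)ccc1C(F)(F)F)c1ccc(S(=O)(=O)c2ccc(O)cc2)cc1` has not been measured; it differs from compound 2 by (4-hydroxyphenyl)sulfonyl in place of (4-hydroxyphenyl)sulfanyl on an aromatic carbon, which is the same change at the same kind of place. Because the earlier step of a 1.8-fold higher number from compound 1 to compound 3 (0.25 log units; within the scatter) stayed within the scatter, the step from compound 2 to compound 4 is expected to be of similar size, a 1.8-fold higher number from compound 2 to compound 4 (0.26 log units; within the scatter). In this assay compound 4 is accordingly estimated at about 30000 nM, with a likely range from 12000 nM to 75000 nM.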

Compound 4, half-maximal inhibitory concentration: 27800 nM
Beside the measured number, compound 4's estimate is 1.1-fold (0.03 log units) above it; the range from low to high includes it.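

In this assay, putting (4-hydroxyphenyl)sulfonyl in place of (4-hydroxyphenyl)sulfanyl on the core of compound 2 gives a 1.7-fold higher number from compound 2 to compound 4 (0.22 log units; within the scatter). The same swap on the core of compound 1 gave a step of matching size, so in this small set the change carries from one core to the other without a visible difference: the same change on two cores in this assay, a 1.8-fold higher number (0.25 log units; within the scatter) from compound 1 to compound 3 and a 1.7-fold higher number (0.22 log units; within the scatter) from compound 2 to compound 4, 1.1-fold (0.02 log units) apart, within the scatter of two such steps. This does not show that the swap itself alters antiproliferative activity, since each step lies within the scatter, and two cores in a single cell line cannot show that it would behave the same way on other cores or in other cells.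

The compounds shown leave open what a different link between the two aromatic rings, such as an ether oxygen or a methylene, would do to the numbers. They also leave open whether an amine or a carboxylic acid in place of the hydroxy group would keep the activity seen here.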